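Solubility of a naphthyl analogue in a quinoline series

The source may report more compounds than this note shows. Statements on the series, on what has been measured and on what is new or still open speak of the compounds shown alone.

Three compounds in this series have a measured number in a physicochemical assay for solubility, with a stated time of 18 h, at pH 7.4; on this read-out lower numbers stand for lower solubility and higher numbers for higher solubility. Compound 1 `COc1ccc(-c2ccc3c(NCCCNCc4cccc(OC)c4O)ccnc3c2)cc1` gives 32000 nM, and compound 2 `COc1cccc(CNCCCNc2ccnc3cc(-c4ccc(F)cc4)ccc23)c1O` gives 32000 nM, with no change at the digits printed from compound 1 to compound 2 (within the scatter). Compound 3 `COc1cccc(CNCCCNc2ccnc3cc(Cc4ccccc4)ccc23)c1O` gives 4200 nM, the lowest of the three numbers: a 7.6-fold lower number from compound 1 to compound 3 (0.88 log units; beyond the scatter) and a 7.6-fold lower number from compound 2 to compound 3 (0.88 log units; beyond the scatter), so compound 3 sits well apart from the other two.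

Compound 4 `COc1cccc(CNCCCNc2ccnc3cc(-c4cccc5ccccc45)ccc23)c1O` has not yet been measured in this assay. It differs from compound 3 in one place: naphthalen-1-yl in place of benzyl on an aromatic carbon. The two steps that bear on this are those into compound 3, each of modest size and each lowering solubility when benzyl replaced a directly attached six-membered ring. Going by the values given here, compound 4 brings back a directly attached aromatic group, but a larger one than in compound 1 or compound 2, and no measured pair shows such a swap. The expected step is therefore small and uncertain in direction, most likely within the scatter, with a 1.2-fold lower number from compound 3 to compound 4 (0.08 log units; within the scatter). The estimate for compound 4 in this assay is 3500 nM, with a plausible range from 600 nM to 20000 nM.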

Compound 4, solubility: 32000 nM
Estimate against measurement, compound 4: 9.1-fold (0.96 log units) below; measured number above the stated range.
By their numbers in this assay, from the lowest: compound 3; then compounds 1, 2 and 4 (each within the scatter of the next).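

At this position on the shared core, this assay gives a 7.6-fold higher number from compound 3 to compound 4 (0.88 log units; beyond the scatter), so the low number of compound 3 does not carry over to a compound with naphthalen-1-yl in place of benzyl. The new group has 2 six-membered aromatic rings where benzyl has one, yet the printed values show no change at the digits printed from compound 2 to compound 4 (within the scatter) and no change at the digits printed from compound 1 to compound 4 (within the scatter), which places compound 3 alone among the four and shows that the larger aromatic group does not move the number away from those of the 4-fluorophenyl and 4-methoxyphenyl compounds. Nothing here gives a measured reason for the gap between benzyl and these three directly attached aromatic groups.

The compounds shown do not tell whether the low number belongs to benzyl alone or would also appear with a longer chain ending in a phenyl ring, such as 2-phenylethyl. They also leave open whether naphthalen-2-yl would match naphthalen-1-yl, and how a group carrying an amine or a carboxylic acid at this position would read out.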